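Trifluoromethyl for Methyl: An Estimate for Compound 4

The source may report more compounds than this note shows. Statements on the series, on what has been measured and on what is new or still open speak of the compounds shown alone.

Measured compounds in an assay on isolated protein for antagonist activity at Rap guanine nucleotide exchange factor 4 (Homo sapiens), read by fluorescence and cAMP accumulation; on this read-out lower numbers stand for stronger inhibition and higher numbers for weaker inhibition:
Compound 1, `COc1ccc(S(=O)(=O)c2c(C)cc(C)cc2C)cc1`, gives 1900 nM.
Compound 2, `Cc1ccc(Nc2c(C)cc(C)cc2C)cc1`, gives 3800 nM.
Compound 3, `CCc1cccn1S(=O)(=O)c1ccc(C)cc1`, gives 4000 nM.

Compound 3 has the highest number of the three. Its nearest neighbour is compound 2, whose number lies within the usual scatter of that of compound 3, so the two cannot be told apart. Compound 1 stands further off, beyond the scatter, with the lower number of the pair.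

Compound 4, `CCc1cccn1S(=O)(=O)c1ccc(C(F)(F)F)cc1`, differs from compound 3 in one place: trifluoromethyl in place of methyl on an aromatic carbon. Among the measured compounds shown here, no pair among the measured compounds shows what such a swap does in this assay, so there is no measured step to lean on. In the absence of such a step, the expected size of the step in this assay is small, with no clear direction and likely within the scatter.

Compound 4 is therefore estimated at 3500 nM, with a range from 1200 nM to 10000 nM, which is the expected step of a 1.1-fold lower number from compound 3 to compound 4 (0.06 log units; within the scatter).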

Compound 4, half-maximal inhibitory concentration: > 300000 nM
Compound 4 ended at the assay's limit (the forecaster's own chance of this, stated with the estimate: 10%); middle value at least 85-fold (1.93 log units) away from the limit.
By their numbers in this assay, from the lowest: compounds 1, 2 and 3 (each within the scatter of the next, the first and the last beyond it). At a limit, above all of these: compound 4.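

In this assay, trifluoromethyl in place of methyl on this aromatic carbon, para to a large group, gives an at least 75-fold higher number from compound 3 to compound 4 (1.87 log units; beyond the scatter). Among the compounds shown here, this shows that the position is not indifferent to the change, which the earlier compounds could not show, as no pair among them differs in one place. The value of compound 4 is a limit of the assay and not a number: the limit of > 300000 nM in this assay, at which 1 of the 4 values shown sits.

The compounds shown leave open whether a chlorine atom, an ethyl group or a nitrile at this position would stay close to compound 3 or also reach the limit. They also leave open whether trifluoromethyl in place of a group on the aromatic ring of compound 1 or compound 2 would have a similar result.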